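Acetyl in place of tert-butyl at a cytotoxicity limit

The source may hold more compounds than are shown below. What is called first, only, known or untested is meant among the compounds shown, and "the series" means these compounds.

Of the compounds shown here, two sharing one core have been tested in an ADME assay on S2 cells (Drosophila melanogaster) for cytotoxicity, read by MTT assay; on this read-out higher numbers stand for an effect only at larger amounts of compound and lower numbers for an effect already at smaller amounts. Compound 1 `Cc1ccc(NC(=O)/C=C/[C@H]2C[C@@H](O)[C@@H](O)C2)cc1` gives > 190000 nM, which is a limit of the assay and not a number. Compound 2 `CC(C)(C)c1ccc(NC(=O)/C=C/[C@H]2C[C@@H](O)[C@@H](O)C2)cc1` gives > 180000 nM, likewise a limit. The step that the two limits leave unreadable from compound 1 to compound 2 therefore cannot be read in size or direction, as both ends rest on the limits the limit of > 180000 nM in this assay, at which 1 of the 2 values shown sits, and (the limit of > 190000 nM in this assay, at which 1 of the 2 values shown sits). Among the compounds with values here, compound 2 thus stands at a limit, and the one further value shown is also a limit.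

Compound 3 `CC(=O)c1ccc(NC(=O)/C=C/[C@H]2C[C@@H](O)[C@@H](O)C2)cc1` has not yet been measured in this assay. It differs from compound 2 by acetyl in place of tert-butyl on an aromatic carbon. Within the data shown here, the only measured step touching this position is the unreadable one from compound 1 to compound 2, so nothing in the numbers points to any direction or size beyond the scatter. Compound 3 is expected to sit at a limit again, an expected step that the limit leaves unreadable from compound 2 to compound 3. The estimate for compound 3 in this assay is 190000 nM, between 60000 nM and 400000 nM.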

Compound 3, half-maximal effective concentration: > 180000 nM
Compound 3: a limit, no number; the forecaster's own chance of this, stated with the estimate: 70%; the middle value does not contradict the limit.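

In this assay compound 3 gives > 180000 nM, a limit and not a number, so its steps from compound 1 and compound 2 cannot be read. The compounds shown leave open how methyl, tert-butyl and acetyl compare in this assay, since none has a measured number.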